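From 4-chlorophenyl to 3-bromophenyl on the amide nitrogen

This account rests on a few compounds, and the source may have more. Where it says the series, first, only, none or still open, it means among the compounds named here.

Compound 1 `CN(C)C(=O)c1cc2cnc(Nc3ccc(NC(=O)C4(C(=O)Nc5ccc(Cl)cc5)CC4)cc3)nc2n1C1CCCC1` carries a 4-chlorophenyl on an amide-type nitrogen. For the measured compounds named here, in a functional assay on A549 cells (Homo sapiens) for inhibition, read by CCK-8 assay, with a stated time of 72 h, tested at 10 uM (on this read-out lower numbers stand for less inhibition of growth and higher numbers for more inhibition of growth at the one concentration tested), compound 1 gives 101%, and its only measured neighbour is compound 2 `COC(=O)c1cccc(NC(=O)C2(C(=O)Nc3ccc(Nc4ncc5cc(C(=O)N(C)C)n(C6CCCC6)c5n4)cc3)CC2)c1`, which in this assay gives 91%. Going by the values given here, the single step between measured compounds, a number 10 percentage points lower from compound 1 to compound 2 (within the scatter), puts 3-(methoxycarbonyl)phenyl in place of 4-chlorophenyl and stays within the scatter, so the two compounds stand level. Compound 3 `CN(C)C(=O)c1cc2cnc(Nc3ccc(NC(=O)C4(C(=O)Nc5cccc(Br)c5)CC4)cc3)nc2n1C1CCCC1` differs from compound 1 thus: 3-bromophenyl in place of 4-chlorophenyl on an amide-type nitrogen. Among the compounds with values here, no measured step exchanges one halogenated phenyl for another; the only bearing comes from that single step, which shows the amide-capping phenyl accepting a change without movement beyond the scatter. A step of a number 6 percentage points lower from compound 1 to compound 3 (within the scatter) is therefore expected, leaving compound 3 near the level of compound 1. Compound 3 is estimated in this assay at 95%, with a range from 80% to 105%.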

Compound 3, percent growth inhibition at one concentration: 92.2%
For compound 3 the middle estimate is 2.8 percentage points above the measured one; measured number inside the range.
By their numbers in this assay, from the lowest: compounds 2, 3 and 1 (each within the scatter of the next).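

Putting 3-bromophenyl in place of 4-chlorophenyl on the amide-type nitrogen gives a number 8.8 percentage points lower from compound 1 to compound 3 (within the scatter) in this assay and so shows that this position also accepts an exchange of one halogenated phenyl for another. Bromo in place of methoxycarbonyl on an aromatic carbon gives a number 1.2 percentage points higher from compound 2 to compound 3 (within the scatter) and places all three compounds level in this assay despite the different groups on this phenyl. No supporting measurement is available to explain this tolerance.

The compounds shown leave open whether a phenyl carrying an amine or a carboxylic acid would stay at this level. For the compounds shown here, they also leave open whether a longer chain in place of the phenyl on the amide-type nitrogen would do so, and a single tested concentration gives no ranking among compounds this close together.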